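Ester side chain: phenoxypropyl replacing methoxyphenyl

The compounds below may be only part of what the source reports. "The series", "measured", "known", "first", "only" and "open" are said of these compounds alone.

Measured so far in an assay on isolated protein for binding affinity to Type-2 angiotensin II receptor (Homo sapiens); on this read-out lower numbers stand for stronger inhibition and higher numbers for weaker inhibition:
compound 1 `CCCCCCCOC(=O)NS(=O)(=O)c1ccccc1-c1ccc(Cn2c(CCC)nc(CC)c2C(=O)OCc2ccccc2OC)c(F)c1` gives 10 nM
compound 2 `CCCc1nc(CC)c(C(=O)OCc2ccccc2OC)n1Cc1ccc(-c2ccccc2S(=O)(=O)NC(=O)OCCC(C)C)cc1F` gives 1 nM

Among the measured compounds shown here, compound 2 gives the lowest of the two numbers in this assay; its nearest neighbour is compound 1, and the single measured step, a 10-fold lower number from compound 1 to compound 2 (1.00 log units; beyond the scatter), concerns the carbamate chain only.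

Compound 3 `CCCc1nc(CC)c(C(=O)OCCCCOc2ccccc2)n1Cc1ccc(-c2ccccc2S(=O)(=O)NC(=O)OCCC(C)C)cc1F` is not yet measured. It differs from compound 2 by 3-phenoxypropyl in place of 2-methoxyphenyl on a saturated chain carbon bound to an oxygen next to a carbonyl group. For the measured compounds named here, no measured step touches this place: the step from compound 1 to compound 2 changes a different part of the molecule and so says nothing about how the ester side chain is tolerated. The expectation therefore rests on compound 2 alone, with a wide range to cover the untested position. Compound 3 is expected to land near compound 2, with a step of a 2.5-fold higher number from compound 2 to compound 3 (0.40 log units; beyond the scatter) that may well fall within the scatter, and an estimated value of 2.5 nM in this assay, between 0.6 nM and 12 nM.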

Compound 3, half-maximal inhibitory concentration: 2 nM
Compound 3: middle estimate off by 1.3-fold (0.10 log units), on the high side; measured number inside the range.
By their numbers in this assay, from the lowest: compounds 2 and 3 (each within the scatter of the next); then compound 1.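

In this assay, the ester side chain now has its first reading, with a 2.0-fold higher number from compound 2 to compound 3 (0.30 log units; within the scatter) for the exchange at this place. On a saturated chain carbon bound to an oxygen next to a carbonyl group, the series therefore takes 3-phenoxypropyl as well as 2-methoxyphenyl with no separation on this read-out, even though the entering group has 10 heavy atoms against 8. The aromatic ring and the single hydrogen-bond acceptor are common to both groups, so these two compounds alone cannot show whether either feature matters here.

Still open, on these data alone, is how this place responds to an amine, a carboxylic acid or a chain longer than 4-phenoxybutyl. No supporting data explain why the two side chains read alike.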